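The compounds below may be only part of what the source reports. "The series", "measured", "known", "first", "only" and "open" are said of these compounds alone.

Measured compounds:
- compound 1 `COC[C@H](C)Oc1cc(Oc2ncc(C(=O)N3CCC3)cc2Cl)cc(C(=O)Nc2cnc(C)cn2)c1`, in a physicochemical assay for lipophilicity; on this read-out lower numbers stand for lower lipophilicity and higher numbers for higher lipophilicity: 2.8
- compound 2 `Cc1cnc(NC(=O)c2cc(Oc3ccc(C(=O)N4CCC4)cc3)cc(O[C@@H](C)CO)c2)cn1`, in this assay: 2.4

Of the two numbers, compound 2 holds the lower one; compound 1 sits higher by a gap that lies beyond the usual scatter. Going by the values given here, the two measured compounds differ in more than one place, so no measured single-point step exists.

Compound 3 `CC(C)n1ccc(NC(=O)c2cc(Oc3ccc(C(=O)N4CCC4)cc3)cc(O[C@@H](C)CO)c2)n1` has not yet been measured in this assay. Relative to compound 2 it differs in one place: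

1-isopropyl-1H-pyrazol-3-yl in place of 5-methylpyrazin-2-yl on an amide-type nitrogen

Among the compounds with values here, nothing among the measured compounds shows what this exchange does on this read-out, so the expectation rests on the change alone. The expected step of a number 0.50 log units higher from compound 2 to compound 3 (beyond the scatter) is upward, moderate in size and somewhat beyond the scatter. Compound 3 is accordingly estimated at 2.9, with a range from 2.4 to 3.4.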

Compound 3, distribution coefficient: 2.8
Compound 3: middle estimate off by 0.10 log units, on the high side, and the stated range covers the measured number.
By their numbers in this assay, from the lowest: compound 2; then compounds 1 and 3 (each within the scatter of the next).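

Going by these compounds alone, at the amide-type nitrogen, the read-out in this assay responds to the exchange of 5-methylpyrazin-2-yl for 1-isopropyl-1H-pyrazol-3-yl, with a number 0.40 log units higher from compound 2 to compound 3 (beyond the scatter) as the first single-place step. The exchange replaces a six-membered aromatic ring with a five-membered one and adds the isopropyl group, while the hydrogen-bond donor and acceptor counts stay the same, so the step belongs to the group exchange as a whole and not to either feature alone. No measured evidence here accounts for the size or direction of this step.

On these data alone, how much of the step follows the ring and how much the isopropyl group remains open. A 1-methyl-1H-pyrazol-3-yl group on the same nitrogen would help separate the two, and the same exchange on the core of compound 1 would test whether the step carries over.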